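Changing the amide aryl group on a tetrazole core

A few compounds are considered here, and "the series" means these few. Any claim that something is new, unique, unknown or untested is made for them only; others in the source may bear on it.

Compound 1 `CCCCCCCCCCCCn1nnnc1C(NC(=O)c1c(C)cccc1C)c1ccccc1`: 180 nM
Compound 2 `CCCCCCCCCCCCn1nnnc1C(NC(=O)c1ccccc1C(F)(F)F)c1ccccc1`: 350 nM

Going by the values given here, in an assay on microsomes from liver for inhibition of sterol O-acyltransferase 1 (Rattus norvegicus) (on this read-out lower numbers stand for stronger inhibition and higher numbers for weaker inhibition), the only step so far, a 1.9-fold higher number from compound 1 to compound 2 (0.29 log units; within the scatter), lies within the scatter, so compound 2 and compound 1 cannot be told apart on these numbers. Compound 3 `CCCCCCCCCCCCn1nnnc1C(NC(=O)c1ccnc(SC)c1)c1ccccc1` differs from compound 2 by a group of 8 heavy atoms (6 carbon, 1 nitrogen, 1 sulfur; one six-membered aromatic ring with 1 hetero atom) in place of a group of 10 heavy atoms (7 carbon, 3 fluorine; one six-membered aromatic ring of carbon only), on a carbonyl carbon. Among the compounds with values here, the one measured step that bears on this, a 1.9-fold higher number from compound 1 to compound 2 (0.29 log units; within the scatter), also exchanged the group on that carbonyl carbon and stayed within the scatter. A similar outcome is expected here, with no step beyond the scatter in this assay. Compound 3 is therefore estimated at 350 nM, ranging from 120 nM to 1000 nM. This expectation corresponds to a step of no change at the digits printed from compound 2 to compound 3 (within the scatter).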

Compound 3, half-maximal inhibitory concentration: 140 nM
Beside the measured number, compound 3's estimate is 2.5-fold (0.40 log units) above it; measured number inside the range.
By their numbers in this assay, from the lowest: compounds 3, 1 and 2 (each within the scatter of the next, the first and the last beyond it).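

In this assay, this position on the carbonyl carbon now shows its first step beyond the scatter: a 2.5-fold lower number from compound 2 to compound 3 (0.40 log units; beyond the scatter), as a six-membered aromatic ring holding nitrogen and sulfur replaces 2-(trifluoromethyl)phenyl. The same group in place of the 2,6-dimethylphenyl ring gives a 1.3-fold lower number from compound 1 to compound 3 (0.11 log units; within the scatter), so those two compounds cannot be told apart, and a ring with a hetero atom fits here without a measurable loss. Nothing measured here explains the larger step. On these data alone, it remains open whether the ring nitrogen or the sulfur matters more, since the two enter together. How an amine on that ring would read is also unknown.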